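The source may report more compounds than this note shows. Statements on the series, on what has been measured and on what is new or still open speak of the compounds shown alone.

Compound 1 `Nc1oncc1-c1ccccc1` carries an amino group on its five-membered ring, and in an assay on SW48 cells for inhibition of Tryptophan 2,3-dioxygenase (Homo sapiens), read by fluorescence, with a stated time of 30 min (a lower number here means that less compound is needed, a higher number that more compound is needed for the effect), compound 1 gives 85 nM. Compound 2 `c1ccc(-c2cnoc2)cc1` lacks that group. In this assay compound 2 reaches only > 25000 nM, which is a limit of the assay rather than a number, as shown by the limit of > 25000 nM in this assay, at which 1 of the 2 values shown sits. The step of an at least 290-fold higher number from compound 1 to compound 2 (2.46 log units; beyond the scatter) shows how much removing the amino group cost. Compound 3 `OCc1oncc1-c1ccccc1` differs from compound 2 by hydroxymethyl in place of hydrogen on an aromatic carbon. On these data alone, whether a hydroxymethyl group can stand in for the lost amino group is untested here, so only part of the loss is expected to be regained, a step of an at least 3.1-fold lower number from compound 2 to compound 3 (0.49 log units; beyond the scatter). Compound 3 is therefore estimated at 8000 nM, with a range from 1000 nM to 30000 nM.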

Compound 3, half-maximal effective concentration: 18000 nM
Compound 3: the middle estimate sits 2.3-fold (0.35 log units) below what was measured; the measured number falls inside the stated range.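

In this assay, hydroxymethyl on this aromatic carbon does not take the place of amino, with a 210-fold higher number from compound 1 to compound 3 (2.33 log units; beyond the scatter) as the step. Compared with hydrogen, it brings no gain that can be told from the scatter, with an at least 1.3-fold lower number from compound 2 to compound 3 (0.14 log units; that floor lies within the scatter) as the step, and that is only a floor. The value of compound 2 is a limit of the assay: the limit of > 25000 nM in this assay, at which 1 of the 3 values shown sits.

On these data alone, what stays open is whether anything other than amino can work on this carbon. A methylamino group or an aminomethyl group there might hold the low number of compound 1 or lose it.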